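Aryl exchange on the shared core: compound 4

This account rests on a few compounds, and the source may have more. Where it says the series, first, only, none or still open, it means among the compounds named here.

Compound 1 `O=C1CSC(c2ccccc2Cl)N1CCN1CCCCC1` is the reference point of this set. Within the data shown here, in an ADME assay on Vero cells (Chlorocebus sabaeus) for cytotoxicity, read by neutral red uptake, tested at 787 ug/mL (a lower number here means a stronger effect, a higher number a weaker effect of the compound at the concentration tested), compound 1 gives 38%, the highest of the three numbers measured so far. Compound 3 `COc1ccccc1C1SCC(=O)N1CCN1CCCCC1` gives 30%; the step of a number 8 percentage points lower from compound 1 to compound 3 (within the scatter) stays within the scatter, so the two compounds are not distinguished by this read-out. Compound 2 `O=C1CSC(c2c(Cl)cccc2Cl)N1CCN1CCCCC1` gives 11%, and the step of a number 27 percentage points lower from compound 1 to compound 2 (beyond the scatter) is the only one in the set that goes beyond the scatter.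

Among the measured compounds shown here, compound 4 `O=C1CSC(c2cccc(O)c2)N1CCN1CCCCC1` differs from compound 1 in one place: 3-hydroxyphenyl in place of 2-chlorophenyl on a saturated ring carbon The change exchanges 2-chlorophenyl for 3-hydroxyphenyl, and no measured step does exactly this. For the measured compounds named here, the nearest precedent, methoxy in place of chloro, gave a number 8 percentage points lower from compound 1 to compound 3 (within the scatter), within the scatter. Going by the values given here, the step of a number 27 percentage points lower from compound 1 to compound 2 (beyond the scatter) shows that a second chloro lowers the number, but the removal of the single chloro has no analogue among the measured compounds. On this basis only a small step is expected, of either sign and most likely none beyond the scatter, with a wide range to reflect the missing precedent. Compound 4 is therefore expected at 32% in this assay, between 14% and 50%. The expected step of a number 6 percentage points lower from compound 1 to compound 4 (within the scatter) would stay within the scatter of the method.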

Compound 4, a percentage reported as activity, at one concentration (the size of the read-out at that concentration, not a potency): 60%
Beside the measured number, compound 4's estimate is 28 percentage points below it; measured number above the stated range.
By their numbers in this assay, from the lowest: compound 2; then compounds 3 and 1 (each within the scatter of the next); then compound 4.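

In this assay, the exchange of 2-chlorophenyl for 3-hydroxyphenyl on the saturated ring carbon gives a number 22 percentage points higher from compound 1 to compound 4 (beyond the scatter), while the added chloro gave a number 27 percentage points lower from compound 1 to compound 2 (beyond the scatter), so changes to the aryl group at this carbon can move the number beyond the scatter in either direction. The two groups have the same number of heavy atoms, but this change removes the chloro, introduces a hydroxy group with a hydrogen-bond donor and acceptor, and alters the substitution pattern of the phenyl ring, so the single step cannot be divided among these differences. No measurement available here accounts for the higher number.

The compounds shown leave open whether the step follows mainly from losing the chloro or from gaining the hydroxy group, a question that a plain phenyl group at this carbon would help to settle. They also leave open whether the higher number is particular to the hydroxy group or also occurs with an amine or a carboxylic acid on the phenyl ring.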